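The source may report more compounds than this note shows. Statements on the series, on what has been measured and on what is new or still open speak of the compounds shown alone.

Series notes, step from compound 3 to compound 4.

Compound 1 `CC(C)c1cc(C(=O)Nc2cccc(NC(=O)CCCCCCC(=O)NO)c2)c(O)cc1O` and compound 2 `CC(C)c1cc(C(=O)Nc2ccc(NC(=O)CCCCCCC(=O)NO)cc2)c(O)cc1O` carry a hydrogen on the amide-type nitrogen of the shared core. In a functional assay on A549 cells (Homo sapiens) for inhibition, read by sulforhodamine B assay, with a stated time of 48 h (a lower number here means a stronger inhibitor of growth, a higher number a weaker inhibitor of growth), compound 1 gives > 10000 nM, which is a limit of the assay and not a number. Compound 2 likewise gives > 10000 nM in this assay, again a limit. For the measured compounds named here, compound 3 `CCN(C(=O)c1cc(C(C)C)c(O)cc1O)c1cccc(NC(=O)CCCCCCC(=O)NO)c1`, with an ethyl on that nitrogen, gives 1590 nM in this assay and is the only compound of the three with a measured number; the series is otherwise characterised by the limit of > 10000 nM in this assay, at which 2 of the 3 values shown sit.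

Going by the values given here, the one measured step that bears on the change is an at least 6.2-fold lower number from compound 1 to compound 3 (0.79 log units; beyond the scatter), so replacing the hydrogen with the ethyl brought the number down out of the limit.

Compound 4 `CC(C)c1cc(C(=O)N(C)c2cccc(NC(=O)CCCCCCC(=O)NO)c2)c(O)cc1O` differs from compound 3 by hydrogen in place of methyl on a saturated chain carbon bound to an amide-type nitrogen. The change runs part of the way back toward compound 1, so the number is expected to rise from compound 3, but less than the whole of the step from compound 1 to compound 3, since a methyl remains on the nitrogen. The expected step is a 2.0-fold higher number from compound 3 to compound 4 (0.30 log units; within the scatter), near the edge of the scatter. Compound 4 is therefore estimated at 3200 nM in this assay, with a range from 1200 nM to 9000 nM.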

Compound 4, concentration for 50% growth inhibition: 2300 nM
Beside the measured number, compound 4's estimate is 1.4-fold (0.14 log units) above it; low and high end bracket the measured number.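

Compound 1 gives > 10000 nM in this assay, which is a limit of the assay and not a number. A methyl in place of the hydrogen on the amide-type nitrogen is already enough to give a measured number, with an at least 4.3-fold lower number from compound 1 to compound 4 (0.63 log units; beyond the scatter), so among the compounds shown the gain is not confined to ethyl. Going from ethyl to methyl on that nitrogen gives a 1.4-fold higher number from compound 3 to compound 4 (0.16 log units; within the scatter), so this assay does not tell these two groups apart, and the presence of either one on the nitrogen, rather than the extra carbon, is what separates compound 3 and compound 4 from compound 1.

Open, as far as these compounds go, is whether a longer chain such as propyl, a branched isopropyl, or a chain ending in an amine or a carboxylic acid on that nitrogen would move the number beyond the scatter, and whether methyl or ethyl on the same nitrogen of compound 2 would bring a measured number there too. The comparisons also remain thinly anchored, with only two measured numbers set against the limit: the limit of > 10000 nM in this assay, at which 2 of the 4 values shown sit.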